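Phenyl to Methyl on the Sulfonyl Across Two Cores

The compounds below may be only part of what the source reports. "The series", "measured", "known", "first", "only" and "open" are said of these compounds alone.

Compound 1 `CN(C)c1cccc2c1ccn2S(=O)(=O)c1ccccc1` and compound 2 `CN(C)c1cccc2c1ccn2S(C)(=O)=O` share one core and differ in a single place: methyl in place of phenyl on a sulfonyl sulfur. In an assay on isolated protein for displacement of a labelled ligand from 5-hydroxytryptamine receptor 6 (Homo sapiens), read by scintillation counting, with a stated time of 1 h (a higher number here means a weaker inhibitor, a lower number a stronger inhibitor), compound 1 gives 65 nM, and compound 2 gives 4720 nM. That single exchange made a large step, a 73-fold higher number from compound 1 to compound 2 (1.86 log units; beyond the scatter).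

Compound 3 `O=S(=O)(c1ccccc1)n1ccc2ccc(-c3ccncc3)cc21` is built on a different core; the difference between the two cores is not broken down here. In this assay compound 3 gives 38 nM, a number within the scatter of compound 1 and well beyond the scatter from compound 2. Compound 4 `CS(=O)(=O)n1ccc2ccc(-c3ccncc3)cc21` stands to compound 3 as compound 2 stands to compound 1: methyl in place of phenyl on a sulfonyl sulfur. The surroundings of the exchange are the same in both pairs, a sulfonyl sulfur whose other neighbour is an aromatic nitrogen, so this is the same change, now carried out on the core of compound 3.

For the measured compounds named here, the expectation for compound 4 therefore rests on the only precedent available. Because that exchange on the first core produced a 73-fold higher number from compound 1 to compound 2 (1.86 log units; beyond the scatter), compound 4 is expected to show a step of comparable size from compound 3, a 66-fold higher number from compound 3 to compound 4 (1.82 log units; beyond the scatter), although a single pair is a thin basis and the second core could respond differently. The estimate for compound 4 in this assay is 2500 nM, with a range from 600 nM to 10000 nM.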

Compound 4, inhibition constant: 4050 nM
The estimate for compound 4 lay 1.6-fold (0.21 log units) below the measured number; measured number inside the range.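

In this assay the exchange of phenyl for methyl on a sulfonyl sulfur whose other neighbour is an aromatic nitrogen again produced a large loss on the second core, a 110-fold higher number from compound 3 to compound 4 (2.03 log units; beyond the scatter). Set beside the step on the first core, the new step does not stand apart from it: the same change on two cores in this assay, a 73-fold higher number (1.86 log units; beyond the scatter) from compound 1 to compound 2 and a 110-fold higher number (2.03 log units; beyond the scatter) from compound 3 to compound 4, 1.5-fold (0.17 log units) apart, within the scatter of two such steps Within this series, then, the size of the change carried over from one core to the other, but this rests on two pairs only, so it establishes no rule for any further core and gives no explanation of why the phenyl group counts for so much.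

The compounds shown hold only phenyl and methyl on the sulfonyl sulfur, so it remains open where along the range from one to the other an ethyl group, a longer chain, a benzyl group or a phenyl carrying a chlorine would fall. Also open, on these data alone, is whether the same step would appear on a core carrying an amine or a carboxylic acid, and how the difference between the two cores themselves divides up in this assay.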